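A few compounds are considered here, and "the series" means these few. Any claim that something is new, unique, unknown or untested is made for them only; others in the source may bear on it.

Within the data shown here, compound 2 `CC(C)c1nc(N)c2nn(-c3ccccc3)cc2n1` stands at 11% in an assay on CHO cells for displacement of a labelled ligand from adenosine receptor A3 (Homo sapiens), read by scintillation counting, tested at 1 uM (a lower number here means less inhibition, a higher number more inhibition at the concentration tested (going by the name of the read-out)), with compound 1 `CC(C)Cc1nc(N)c2nn(-c3ccccc3)cc2n1` as its only comparison at 13%; the step of a number 2 percentage points lower from compound 1 to compound 2 (within the scatter) lies within the scatter. Compound 3 `Cc1cccc(Cc2nc(N)c3nn(-c4ccccc4)cc3n2)c1` carries 3-methylbenzyl in place of isopropyl on an aromatic carbon. Among the measured compounds shown here, the one measured step bears on this only loosely, since it exchanges two small alkyl groups while the new group brings in a ring, so a modest rise is expected rather than a firm one, estimated as a number 11 percentage points higher from compound 2 to compound 3 (beyond the scatter). Compound 3 is therefore expected to give 22%, between 5% and 48%.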

Compound 3, a percentage reported as inhibition, at one concentration (the size of the read-out at that concentration, not a potency): 11%
For compound 3 the middle estimate is 11 percentage points above the measured one, and the stated range covers the measured number.
By their numbers in this assay, from the lowest: compounds 2, 3 and 1 (each within the scatter of the next).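

In this assay, putting 3-methylbenzyl in place of isopropyl gives no change at the digits printed from compound 2 to compound 3 (within the scatter), and putting 3-methylphenyl in place of the isopropyl end of the isobutyl group gives a number 2 percentage points lower from compound 1 to compound 3 (within the scatter). So at this position, between two ring nitrogen atoms, adding a six-membered aromatic ring leaves the inhibition within the scatter of the two small alkyl groups. Nothing available explains this result. From the compounds shown here alone, whether an amine or a carboxylic acid at this position would shift the number beyond the scatter remains open.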